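Hydroxamic acid series: heteroaryl swap on the triazole core

The source may hold more compounds than are shown below. What is called first, only, known or untested is meant among the compounds shown, and "the series" means these compounds.

Measured so far:
- compound 1 `Cc1cc(-c2nnc(Sc3c(F)cc(C(=O)NO)cc3F)n2C)nn1C`: 6 nM
- compound 2 `O=C(O)c1cccc(-c2nnn(Cc3ccc(C(=O)NO)cc3)n2)c1`: 12 nM
- compound 3 `O=C(NO)c1ccc(Cn2nnc(-c3ccccn3)n2)cc1`: 9 nM

All three were run in an assay on Sf9 cells for inhibition of protein deacetylase HDAC6 (Homo sapiens), read by fluorescence; a lower number here means a stronger inhibitor, a higher number a weaker inhibitor. In this assay compound 1 gives 6 nM, the lowest of the three numbers, but its gap to compound 3 at 9 nM and to compound 2 at 12 nM both lie within the usual scatter, so no order among the three can be claimed from these values.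

For the measured compounds named here, the next compound, compound 4 `Cn1c(Sc2c(F)cc(C(=O)NO)cc2F)nnc1-c1cccnn1`, keeps the core of compound 1 and alters only one group: pyridazin-3-yl in place of 1,5-dimethyl-1H-pyrazol-3-yl on an aromatic carbon. The 1,5-dimethyl-1H-pyrazol-3-yl leaves and a pyridazin-3-yl enters; both carry two ring nitrogen atoms and no hydrogen-bond donor. Going by the values given here, no pair of measured compounds differing in one place is available, so the size of this step is not anchored by data.

The expectation is that the step from compound 1 to compound 4 in this assay stays within the scatter, a 1.5-fold higher number from compound 1 to compound 4 (0.18 log units; within the scatter), with no direction beyond it. Compound 4 is therefore estimated at 9 nM, with a range from 4 nM to 25 nM.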

Compound 4, half-maximal inhibitory concentration: 13 nM
Compound 4: the middle estimate sits 1.4-fold (0.16 log units) below what was measured; the measured number falls inside the stated range.
By their numbers in this assay, from the lowest: compounds 1, 3, 2 and 4 (each within the scatter of the next, the first and the last beyond it).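

For the compounds shown here, this is the first step that can be read at one position: on the aromatic carbon of the five-membered aromatic ring with 3 nitrogen, pyridazin-3-yl in place of 1,5-dimethyl-1H-pyrazol-3-yl gives a 2.2-fold higher number from compound 1 to compound 4 (0.34 log units; beyond the scatter) in this assay, a modest change that only just passes the scatter. The position therefore accepts a six-membered aromatic ring in place of a five-membered one, with the count of ring hetero atoms, donors and acceptors unchanged, and compound 4 still gives 13 nM in this assay. No measurement shown bears on what lies behind this step.

Going by these compounds alone, with only this one step at the position, the data cannot separate the change in ring size from the loss of the two methyl groups, and it remains open whether the step would carry over to another core. A phenyl ring with no ring nitrogen, or a morpholine, on the same carbon would show whether ring nitrogen atoms or an aromatic ring are needed here at all.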